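The compounds below may be only part of what the source reports. "The series", "measured", "known", "first", "only" and "open" are said of these compounds alone.

Compound 1 `COc1ccc(-n2nc(C(N)=O)nc2-c2cc(OC)c(OC)c(OC)c2)cc1` gives 40% in a functional assay on the whole organism for inhibition, with Rattus norvegicus as the target, read by paw edema, with stated times of 30 min and 1 h, at a dose of 0.28 mmol/kg by the oral route; a higher number here means more inhibition at the dose given (going by the name of the read-out), a lower number less inhibition.
Compound 2 `CNC(=O)c1nc(-c2cc(OC)c(OC)c(OC)c2)n(-c2ccc(OC)cc2)n1` gives 56% in this assay.

Among these two numbers compound 2 stands highest, ahead of compound 1 by a number 16 percentage points higher from compound 1 to compound 2 (beyond the scatter). Compound 3 `CCNC(=O)c1nc(-c2cc(OC)c(OC)c(OC)c2)n(-c2ccc(OC)cc2)n1` differs from compound 2 in one place: methyl in place of hydrogen on a saturated chain carbon bound to an amide-type nitrogen. Going by the values given here, only one measured step bears on it, the change a number 16 percentage points higher from compound 1 to compound 2 (beyond the scatter), which also adds a methyl, though directly on the amide-type nitrogen rather than one bond further out. One step of that size does not show whether lengthening the chain by a further methyl carries the gain on, holds it, or gives some of it back. The expected outcome is therefore a step of a number 1 percentage points higher from compound 2 to compound 3 (within the scatter) in this assay, within the scatter. Compound 3 is estimated to give 57%, with a plausible range from 40% to 74%.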

Compound 3, a percentage reported as inhibition, in the whole organism at one dose (the size of the read-out at that dose, not a potency): 60%
For compound 3 the middle estimate is 3 percentage points below the measured one; the range from low to high includes it.
By their numbers in this assay, from the lowest: compound 1; then compounds 2 and 3 (each within the scatter of the next).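

In this assay, the step that lengthens methyl to ethyl (a number 4 percentage points higher from compound 2 to compound 3 (within the scatter)) lies within the scatter, so the added methyl on the saturated chain carbon bound to the amide-type nitrogen shows no gain or loss beyond it. This adds something that the first step could not show: the gain does not depend on methyl alone, since ethyl in place of the hydrogen on the amide-type nitrogen also gives a step beyond the scatter (a number 20 percentage points higher from compound 1 to compound 3 (beyond the scatter)). No measurement here explains why the two groups read alike.

As far as these compounds go, whether a longer chain, such as propyl or butyl, would hold this level on the amide-type nitrogen remains open. The same is true of a branched isopropyl group or a cyclopropyl ring at that nitrogen.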